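The compounds below may be only part of what the source reports. "The series", "measured", "known", "first", "only" and "open" are said of these compounds alone.

Compound 2 `Cc1cccc(-c2noc(C3CN(S(=O)(=O)c4ccc(Cl)cc4)C3)n2)c1` carries a 4-chlorophenyl group on its sulfonyl sulfur. In an assay on HEK293 cells for positive allosteric modulation of metabotropic glutamate receptor 5 (Homo sapiens), read by FLIPR (a higher number here means that more compound is needed for the effect, a lower number that less compound is needed), compound 2 gives > 10000 nM, which is a limit of the assay rather than a number. Compound 1 `Cc1cccc(-c2noc(C3CN(S(=O)(=O)c4cccc(C)c4)C3)n2)c1`, with 3-methylphenyl on that sulfur, gives > 10000 nM in this assay, again a limit. Between them lies a step that the two limits leave unreadable from compound 1 to compound 2, so nothing can be read from that pair about how the group on the sulfur matters. Compound 3 `Cc1ccc(S(=O)(=O)N2CC(c3nc(-c4cccc(C)c4)no3)C2)cc1` differs from compound 2 by methyl in place of chloro on an aromatic carbon; cut one bond further out, this reads 4-chlorophenyl to 4-methylphenyl. Among the compounds with values here, the only evidence is the limit of > 10000 nM in this assay, at which 2 of the 2 values shown sit, which says nothing about the size or direction of such a change. The step is therefore expected to be a step that the limit leaves unreadable from compound 2 to compound 3, with a high chance that only a limit is reported again. For compound 3 the estimate is 15000 nM, ranging from 5000 nM to 50000 nM.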

Compound 3, half-maximal effective concentration: > 10000 nM
Compound 3 was reported as a limit (the forecaster's own chance of this, stated with the estimate: 80%); the middle value lies beyond the limit too.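

In this assay, within the data shown here, compound 3 gives > 10000 nM, again a limit and not a number, so no step among compound 1, compound 2 and compound 3 can be read. The compounds shown leave open whether any group on the sulfonyl sulfur gives a measurable value in this assay.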